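The compounds below may be only part of what the source reports. "The series", "measured", "known", "first", "only" and "open" are said of these compounds alone.

Measured in a functional assay on PC-3 cells (Homo sapiens) for cytotoxicity, read by MTT assay, with a stated time of 72 h; on this read-out higher numbers stand for weaker inhibition and lower numbers for stronger inhibition:
- Compound 1 `CC(C)(C)c1cc(/C=N/NC(=O)Nc2cc3c(Nc4ccc(F)c(Cl)c4)ncnc3cc2O[C@H]2CCOC2)cc(C(C)(C)C)c1O`: 13100 nM
- Compound 2 `COc1cc2ncnc(Nc3ccc(F)c(Cl)c3)c2cc1NC(=O)N/N=C/c1cccc(Br)c1`: "not active" (no number reported)

Among the measured compounds shown here, compound 1 holds the only number in this small set. Compound 2 was reported without one, so compound 1 cannot be placed on a scale against any other compound. Compound 3 `COc1cc2ncnc(Nc3ccc(F)c(Cl)c3)c2cc1NC(=O)N/N=C/c1cc(C(C)(C)C)c(O)c(C(C)(C)C)c1` has not yet been measured, and it differs from compound 1 in one place: methyl in place of oxolan-3-yl on an oxygen on an aromatic ring. For the measured compounds named here, no measured pair shows the size of this change. With compound 1 at 13100 nM as the sole anchor, no step beyond the scatter is expected in this assay, in either direction. The estimated step is a 1.1-fold higher number from compound 1 to compound 3 (0.06 log units; within the scatter). For compound 3 the expected value is 15000 nM, with an estimated range from 5000 nM to 45000 nM.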

Compound 3, half-maximal inhibitory concentration: 28700 nM
Compound 3: the middle estimate sits 1.9-fold (0.28 log units) below what was measured; the measured number falls inside the stated range.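

In this assay, the change from (oxolan-3-yl)oxy to methoxy comes with a 2.2-fold higher number from compound 1 to compound 3 (0.34 log units; beyond the scatter), which gives this position its first measured step: a modest one, in the direction of weaker inhibition. The oxolan-3-yl group, with its ring and defined stereocentre, is therefore not needed for a numerical read-out, since compound 3 still gives 28700 nM, though the step does favour the larger group in this pair. Nothing at hand explains the difference between the two compounds.

The compounds shown leave open whether the step follows the ring itself or its ring oxygen, which a cyclopentyl group on the same oxygen would separate. They also leave open how an ethyl group or a longer chain ending in an amine would read at this place.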